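Compound 2 to compound 3: ethynyloxy at the same carbon

A few compounds are considered here, and "the series" means these few. Any claim that something is new, unique, unknown or untested is made for them only; others in the source may bear on it.

In an ADME assay on L1210/0 cells (Mus musculus) for cytotoxicity, with a stated time of 48 h (on this read-out higher numbers stand for weaker inhibition and lower numbers for stronger inhibition), compound 1 (`C=C(Cl)c1cn([C@H]2C[C@H](O)[C@@H](CO)O2)c(=O)[nH]c1=O`) reads 1660 nM as a measured number. In this assay compound 2 (`C=CC#Cc1cn([C@H]2C[C@H](O)[C@@H](CO)O2)c(=O)[nH]c1=O`) reads > 200000 nM and that is a limit of the assay, not a number. Among the compounds with values here, the one measured step is an at least 120-fold higher number from compound 1 to compound 2 (2.08 log units; beyond the scatter) and it is large, with a group of 4 heavy atoms (4 carbon; no ring) replacing a group of 3 heavy atoms (2 carbon, 1 chlorine; no ring) on an aromatic carbon.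

Compound 3 (`C#COc1cn([C@H]2C[C@H](O)[C@@H](CO)O2)c(=O)[nH]c1=O`) differs from compound 2 at that same carbon (a group of 3 heavy atoms (2 carbon, 1 oxygen; no ring) in place of a group of 4 heavy atoms (4 carbon; no ring), on an aromatic carbon) and carries ethynyloxy, a group of 3 heavy atoms. Compound 1 at 1660 nM shows that a group of 3 heavy atoms here can give a measured number. A step toward lower numbers in this assay is therefore expected, beyond the scatter but smaller than the measured one, and a second reading at the limit remains quite possible. The expected change is an at least 5.0-fold lower number from compound 2 to compound 3 (0.69 log units; beyond the scatter) on this estimate. For compound 3 the estimated value is 40000 nM with an expected range from 4000 nM to 200000 nM as a rough guide.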

Compound 3, half-maximal inhibitory concentration: > 200000 nM
Compound 3: a limit, no number (the forecaster's own chance of this, stated with the estimate: 40%); middle value at least 5.0-fold (0.69 log units) away from the limit.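

In this assay compound 3 reads > 200000 nM, which is a limit of the assay and not a number, so ethynyloxy on this aromatic carbon gives no measured value. Set against 1-chloroethenyl, the change is large, an at least 120-fold higher number from compound 1 to compound 3 (2.08 log units; beyond the scatter), and it shows what compound 2 could not: a group of 3 heavy atoms at this position does not by itself bring a measured number, so heavy-atom count alone does not separate the reading of compound 1 from the other two. The step between compound 2 and compound 3 cannot be read, and no order between these two follows from the shared ceiling: the limit of > 200000 nM in this assay, at which 2 of the 3 values shown sit.

The compounds shown leave open whether the chlorine or the double bond of 1-chloroethenyl goes with the measured reading, as compound 1 alone gives a number at this carbon. Also open, from the compounds shown here alone, is how a plain ethenyl group, a single bromine atom or an amine at the same carbon would read in this assay, and whether any of them would give a number at all.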